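Bromo for Iodo: a Small Halogen Swap on Compound 3

The source may hold more compounds than are shown below. What is called first, only, known or untested is meant among the compounds shown, and "the series" means these compounds.

Measured compounds:
compound 1 `CC(C)(C)c1ccc(C(=O)/C=C/c2ccc([N+](=O)[O-])o2)cc1`: > 50000 nM
compound 2 `O=C(/C=C/c1ccc([N+](=O)[O-])o1)c1ccc(-n2ccnc2)cc1`: 22200 nM
compound 3 `COc1ccc(/C=C/C(=O)c2cccc(I)c2)cc1`: > 50000 nM

All three were tested in an ADME assay on THP-1 cells (Homo sapiens) for cytotoxicity, read by resazurin assay, with a stated time of 72 h; a lower number here means that less compound is tolerated, a higher number that more compound is tolerated. Compound 3 gives only a limit of the assay, not a number. Indeed (the limit of > 50000 nM in this assay, at which 2 of the 3 values shown sit). For the measured compounds named here, the single measured step, an at least 2.2-fold lower number from compound 1 to compound 2 (0.35 log units; beyond the scatter), involves a different group on a different compound.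

Compound 4 `COc1ccc(/C=C/C(=O)c2cccc(Br)c2)cc1` differs from compound 3 by bromo in place of iodo on an aromatic carbon. Going by the values given here, no measured step bears on such a halogen swap, so no change beyond the usual scatter is expected. The estimated step from compound 3 to compound 4 is a step that the limit leaves unreadable from compound 3 to compound 4. Compound 4 is therefore expected to give about 60000 nM, between 25000 nM and 150000 nM, most likely reported again only as a limit.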

Compound 4, half-maximal cytotoxic concentration: > 50000 nM
Compound 4: a limit, no number; the forecaster's own chance of this, stated with the estimate: 75%; the middle value is on the limit's open side.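

Compound 3 and compound 4 each give only a limit, not a number, so no step can be read between them: the limit of > 50000 nM in this assay, at which 3 of the 4 values shown sit.

As far as these compounds go, whether bromo in place of iodo changes how much compound the cells tolerate stays open.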